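The source may hold more compounds than are shown below. What is called first, only, known or untested is meant among the compounds shown, and "the series" means these compounds.

Working notes on the series. The three measured compounds share one core and differ only in the aryl group on a saturated chain carbon, two bonds along the chain from a carbonyl carbon. Compound 1 `CC(C)C[C@H](N)c1cc(C(F)(F)F)ccc1N1CCN(C(=O)CCc2cccc(C(F)(F)F)c2)CC1` gives 2200 nM in an assay on HEK293 cells for displacement of a labelled ligand from Melanocortin receptor 4 (Homo sapiens); on this read-out higher numbers stand for weaker inhibition and lower numbers for stronger inhibition. Compound 2 `CC(C)C[C@H](N)c1cc(C(F)(F)F)ccc1N1CCN(C(=O)CCc2ccc(S(C)(=O)=O)cc2)CC1` gives 4900 nM in this assay, and compound 3 `COc1ccc(OC)c(CCC(=O)N2CCN(c3ccc(C(F)(F)F)cc3[C@@H](N)CC(C)C)CC2)c1` gives 2500 nM. Compound 3 stands second highest of the three numbers; its gap to compound 1 and its gap to compound 2 both lie within the scatter, so no order among the three is claimed. Of the measured steps, only a 2.2-fold higher number from compound 1 to compound 2 (0.35 log units; beyond the scatter) reaches beyond the scatter, and it is modest; a 1.1-fold higher number from compound 1 to compound 3 (0.06 log units; within the scatter) and a 2.0-fold lower number from compound 2 to compound 3 (0.29 log units; within the scatter) stay within the scatter.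

Compound 4 `CC(C)C[C@H](N)c1cc(C(F)(F)F)ccc1N1CCN(C(=O)CCc2cn(C)c3ccccc23)CC1` is not yet measured. It differs from compound 3 by 1-methyl-1H-indol-3-yl in place of 2,5-dimethoxyphenyl on a saturated chain carbon, two bonds along the chain from a carbonyl carbon. All three measured steps bear on this change, since each of them swaps the aryl group at the same place, and none moved the number by more than a modest amount. The expected step is therefore no change at the digits printed from compound 3 to compound 4 (within the scatter), with no direction beyond the scatter. For compound 4 the estimated value in this assay is 2500 nM, with a range of 1000 nM to 6500 nM.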

Compound 4, inhibition constant: 3000 nM
Compound 4: middle estimate off by 1.2-fold (0.08 log units), on the low side, and the stated range covers the measured number.
By their numbers in this assay, from the lowest: compounds 1, 3, 4 and 2 (each within the scatter of the next, the first and the last beyond it).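

The place on a saturated chain carbon, two bonds along the chain from a carbonyl carbon, now also carries 1-methyl-1H-indol-3-yl, with one five-membered aromatic ring with 1 hetero atom alongside a six-membered aromatic ring of carbon only, and this assay shows a 1.2-fold higher number from compound 3 to compound 4 (0.08 log units; within the scatter) in place of 2,5-dimethoxyphenyl. Going by these compounds alone, measured against the two other aryl groups, the same group gives a 1.4-fold higher number from compound 1 to compound 4 (0.13 log units; within the scatter) and a 1.6-fold lower number from compound 2 to compound 4 (0.21 log units; within the scatter), so it sits within the scatter of both, while a 2.2-fold higher number from compound 1 to compound 2 (0.35 log units; beyond the scatter) remains the only step beyond the scatter. No evidence is at hand on why the number stays so close across these aryl groups.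

Still open, from the compounds shown here alone, is whether the number moves further with 1H-indol-3-yl lacking the methyl group, with a carboxylic acid or an aminomethyl group on the aryl ring, or with a longer chain leading to the aryl group. The shared core is the same in all four compounds, so nothing here tells whether this flat picture at the aryl group would hold on a different core.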